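Leaving methoxy: a naphthalen-1-yl swap on compound 3

A few compounds are considered here, and "the series" means these few. Any claim that something is new, unique, unknown or untested is made for them only; others in the source may bear on it.

- compound 1 `Ic1ccc(C2CC(c3ccc4c(c3)OCCO4)=NN2c2ccccc2)cc1`: 3470 nM
- compound 2 `CSc1ccc(C2CC(c3ccc4c(c3)OCCO4)=NN2c2ccccc2)cc1`: 6870 nM
- compound 3 `COc1ccc(C2CC(c3ccc4c(c3)OCCO4)=NN2c2ccccc2)cc1`: > 100000 nM

All three values come from a functional assay on WM 266-4 cells (Homo sapiens) for antiproliferative activity, read by MTT assay, with a stated time of 24 h; on this read-out lower numbers stand for stronger inhibition of growth and higher numbers for weaker inhibition of growth. Compound 3 sits at > 100000 nM, which is a limit of the assay and not a number, and it is the weakest of the three. Compound 4 `c1ccc(N2N=C(c3ccc4c(c3)OCCO4)CC2c2cccc3ccccc23)cc1` carries naphthalen-1-yl in place of 4-methoxyphenyl on a saturated ring carbon. The steps bearing on this change are an at least 28-fold higher number from compound 1 to compound 3 (1.45 log units; beyond the scatter) and an at least 14-fold higher number from compound 2 to compound 3 (1.16 log units; beyond the scatter), both large, while a 2.0-fold higher number from compound 1 to compound 2 (0.30 log units; within the scatter) stays within the scatter. Among the compounds with values here, no naphthalen-1-yl compound has been measured, so the reading is indirect, but a large step towards a lower number is expected in this assay. The estimated step is an at least 8.3-fold lower number from compound 3 to compound 4 (0.92 log units; beyond the scatter). Compound 4 is expected at 12000 nM, with an estimated range of 2500 nM to 60000 nM.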

Compound 4, concentration for 50% growth inhibition: > 100000 nM
Compound 4: no number, only a limit (the forecaster's own chance of this, stated with the estimate: 25%); middle value at least 8.3-fold (0.92 log units) away from the limit.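

In this assay compound 4 gives > 100000 nM, a limit of the assay and not a number. On this saturated ring carbon, naphthalen-1-yl therefore gives no measurable value, so a second six-membered aromatic ring does not restore what 4-methoxyphenyl lacks, with an at least 28-fold higher number from compound 1 to compound 4 (1.45 log units; beyond the scatter) and an at least 14-fold higher number from compound 2 to compound 4 (1.16 log units; beyond the scatter). The step between compound 3 and compound 4 cannot be read: the limit of > 100000 nM in this assay, at which 2 of the 4 values shown sit.

Still open, going by these compounds, is whether an amine or a carboxylic acid on the phenyl group at this carbon would give a measurable value. On these data alone, the true values of compound 3 and compound 4 also remain unknown.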